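Morpholine to piperidine at a thiocarbonyl carbon

The source may report more compounds than this note shows. Statements on the series, on what has been measured and on what is new or still open speak of the compounds shown alone.

Compound 2, `COc1ccc2oc(CSC(=S)N3CCOCC3)cc(=O)c2c1`: > 25000 nM
Compound 1, `CCOC(=O)c1cc(=O)c2cc(CSC(=S)N(C)c3ccccc3)ccc2o1`: > 25000 nM

In a functional assay on MCF7 cells (Homo sapiens) for antiproliferative activity, read by MTT assay, with a stated time of 72 h (on this read-out higher numbers stand for weaker inhibition and lower numbers for stronger inhibition), compound 2 gives > 25000 nM, which is a limit of the assay rather than a measured number. Compound 1 likewise gives > 25000 nM in this assay, again a limit. Going by the values given here, both values therefore sit at the limit of > 25000 nM in this assay, at which 2 of the 2 values shown sit, so compound 2 stands nowhere in particular among the numbers: nothing separates it from compound 1, and no measured step exists to show how any change moves the read-out. Compound 3, `COc1ccc2oc(CSC(=S)N3CCCCC3)cc(=O)c2c1`, differs from compound 2 by piperidin-1-yl in place of morpholin-4-yl on a thiocarbonyl carbon. Among the compounds with values here, with no measured step to lean on, no move beyond the usual scatter is expected in this assay for this change, in either direction. Compound 3 is therefore expected to give about 30000 nM, between 10000 nM and 100000 nM, most likely again reported only as a limit. The expected step is a step that the limit leaves unreadable from compound 2 to compound 3.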

Compound 3, half-maximal inhibitory concentration: 10000 nM
Compound 3: middle estimate off by 3.0-fold (0.48 log units), on the high side, within the range that was stated.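

Going by these compounds alone, replacing morpholin-4-yl with piperidin-1-yl on a thiocarbonyl carbon produces the first step that can be read in this assay: the change gives an at least 2.5-fold lower number from compound 2 to compound 3 (0.39 log units; beyond the scatter). Within the data shown here, the group at this position can therefore move the read-out, something the earlier compounds could not show, and here the two groups differ by one ring atom, with carbon in place of oxygen. The true size of the step remains unknown because the value of compound 2 is only a limit: the limit of > 25000 nM in this assay, at which 2 of the 3 values shown sit.

Going by these compounds, it remains open whether piperazin-1-yl or an open-chain amine such as diethylamino at this thiocarbonyl carbon would lower the number further. A single step also cannot tell whether piperidin-1-yl would have a similar effect on the core of compound 1.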